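The source may report more compounds than this note shows. Statements on the series, on what has been measured and on what is new or still open speak of the compounds shown alone.

Measured compounds:
compound 1 `CCCCC(CC)C(=O)Nc1ccc2ccn(Cc3c(OC)cc(C(=O)NS(=O)(=O)c4ccccc4)cc3OC)c2c1` gives 8
compound 2 `CCCCC(CC)C(=O)Nc1ccc2ccn(Cc3ccc(C(=O)NS(=O)(=O)c4ccccc4C)cc3OC)c2c1` gives 8.9
compound 3 `CCCCC(CC)C(=O)Nc1ccc2ccn(Cc3ccc(C(=O)NS(=O)(=O)c4ccc(OC)cc4)cc3OC)c2c1` gives 7.4

Compound 3 stands lowest of the three measured compounds in a functional assay (trachea) for antagonist activity, with Cavia porcellus as the target; a lower number here means a less potent compound, a higher number a more potent compound, by a factor of ten per unit of this negative logarithm. The value for compound 1 is higher than that of compound 3, and the value for compound 2 is higher still. Within the data shown here, the only single-point step among the measured compounds, a number 1.50 log units lower from compound 2 to compound 3 (beyond the scatter), is large and leads downward to the 4-methoxyphenyl group on the sulfonyl sulfur.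

Compound 4 `CCCCC(CC)C(=O)Nc1ccc2ccn(Cc3ccc(C(=O)NS(=O)(=O)c4ccccc4)cc3OC)c2c1` is not yet measured. Compared with compound 3 it carries hydrogen in place of methoxy on an aromatic carbon. Among the measured compounds shown here, no measured step shows this exact change on this core, since compound 1, which carries the phenylsulfonyl group, differs from compound 4 elsewhere as well. The large step of a number 1.50 log units lower from compound 2 to compound 3 (beyond the scatter) nonetheless suggests that the 4-methoxyphenyl group on the sulfonyl sulfur is associated with the lowest number in this set, so removing it is expected to move the number upward by a number 0.80 log units higher from compound 3 to compound 4 (beyond the scatter). Compound 4 is therefore estimated to give 8.2 in this assay, with a range from 7.5 to 8.9.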

Compound 4, negative logarithm of the antagonist equilibrium constant: 8.6
Beside the measured number, compound 4's estimate is 0.40 log units below it; low and high end bracket the measured number.
By their numbers in this assay, from the lowest: compound 3; then compound 1; then compounds 4 and 2 (each within the scatter of the next).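

In this assay, removing the methoxy that stands para to a large group gives a number 1.20 log units higher from compound 3 to compound 4 (beyond the scatter) on the sulfonyl side, so the low number of compound 3 goes with that methoxy being present, not with the methyl of compound 2 being absent. The methyl itself makes no readable difference, with a number 0.30 log units lower from compound 2 to compound 4 (within the scatter) in this comparison. A further methoxy on the other aromatic ring also goes with a lower number, since taking it away gives a number 0.60 log units higher from compound 1 to compound 4 (beyond the scatter) for this change.

No available information bears on why either methoxy matters. From the compounds shown here alone, it remains open whether another group on that aromatic carbon, such as an amine or a chlorine atom, would track the methoxy or the hydrogen, and whether the step holds with a different acyl chain.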